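The compounds below may be only part of what the source reports. "The series", "measured", "known", "first", "only" and "open" are said of these compounds alone.

The series shares one core in which a triazole links two methoxylated phenyl rings. Compound 3 `COc1cc(OC)cc(-c2cn(-c3cc(OC)c(OC)c(OC)c3)nn2)c1` stands where the other two stand. In a functional assay on MDA-MB-231 cells (Homo sapiens) for cytotoxicity, read by MTT assay (on this read-out lower numbers stand for stronger inhibition and higher numbers for weaker inhibition), compound 3 gives > 10000 nM, which is a limit of the assay and not a number. Compound 1 `COc1cc(-c2cn(-c3cc(OC)c(OC)c(OC)c3)nn2)cc(OC)c1OC` in this assay gives > 10000 nM, again a limit. Compound 2 `COc1cc(OC)cc(-c2cn(-c3ccc(OC)c(O)c3)nn2)c1` in this assay gives > 10000 nM, also a limit. Among the compounds with values here, the only step recorded between neighbours, a step that the two limits leave unreadable from compound 1 to compound 3, is unreadable since both of its ends sit at the limit of > 10000 nM in this assay, at which 3 of the 3 values shown sit. Compound 4 `COc1cc(OC)cc(-c2cn(-c3ccc(OC)c(OC)c3)nn2)c1` differs from compound 3 in one place: hydrogen in place of methoxy on an aromatic carbon. Within the data shown here, the single step that bears on this kind of change is the unreadable one, so the size and direction expected for the step from compound 3 to compound 4 in this assay rest on nothing beyond three limits, and no shift beyond the scatter can be argued either way. On that footing compound 4 is expected to give 15000 nM in this assay, within 4000 nM to 60000 nM, most likely reported once more as a limit rather than a number. The resulting step is estimated as a step that the limit leaves unreadable from compound 3 to compound 4.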

Compound 4, half-maximal inhibitory concentration: 10000 nM
Beside the measured number, compound 4's estimate is 1.5-fold (0.18 log units) above it; low and high end bracket the measured number.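

In this assay, hydrogen in place of methoxy on an aromatic carbon gives the series its first measured number, with a number no higher from compound 3 to compound 4 (the limit leaves the size open). Methyl in place of hydrogen on an oxygen on an aromatic ring reads the same way, with a number no higher from compound 2 to compound 4 (the limit leaves the size open). Both steps therefore show only a direction and no readable size, and the series remains at the edge of what this read-out can resolve: the limit of > 10000 nM in this assay, at which 3 of the 4 values shown sit.

Going by these compounds, whether either change moves activity beyond the usual scatter stays open, since compound 2 and compound 3 have limits rather than numbers. Also open, on these data alone, is what an amine or a carboxylic acid on this aromatic carbon, ortho to a methoxy group, would give in this assay.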